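The compounds below may be only part of what the source reports. "The series", "measured", "known", "first", "only" and "open" are said of these compounds alone.

Measured in an ADME assay on the whole organism (strain Sprague-Dawley) for metabolic stability, with Rattus norvegicus as the target, at a dose of 10 mg/kg by the oral route; on this read-out higher numbers stand for a longer-lived compound and lower numbers for a shorter-lived compound:
- compound 1 `COc1nc2cccnc2n1-c1ccc(Nc2ccc(C)cn2)cc1`: 3.78 h
- compound 2 `COc1nc2cccnc2n1-c1ccc(Nc2nc3ccccc3s2)cc1`: 3.24 h

Among the compounds with values here, compound 1 stands level with compound 2, the only other measured compound, as the step is a 1.2-fold lower number from compound 1 to compound 2 (0.07 log units; within the scatter). Compound 3 `CCCc1nc2cccnc2n1-c1ccc(Nc2ccc(C)cn2)cc1` carries one change from compound 1: propyl in place of methoxy on an aromatic carbon. Within the data shown here, no measured step touches this place. The one available, a 1.2-fold lower number from compound 1 to compound 2 (0.07 log units; within the scatter), concerns the group on a nitrogen on an aromatic ring and gives only weak guidance. In this assay, no shift beyond the scatter is therefore expected, and the expected change is a 1.2-fold lower number from compound 1 to compound 3 (0.07 log units; within the scatter). Compound 3 is estimated at 3.2 h, with an expected range of 1.4 h to 6.8 h.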

Compound 3, half-life: 0.91 h
Compound 3: the middle estimate sits 3.5-fold (0.55 log units) above what was measured, outside the stated range (below it).
By their numbers in this assay, from the lowest: compound 3; then compounds 2 and 1 (each within the scatter of the next).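

In this assay, the place on the five-membered aromatic ring, between two ring nitrogen atoms, is sensitive to substitution: with propyl in place of methoxy, the step is a 4.2-fold lower number from compound 1 to compound 3 (0.62 log units; beyond the scatter), beyond the scatter. The change on the nitrogen, by contrast, gives a 1.2-fold lower number from compound 1 to compound 2 (0.07 log units; within the scatter), within the scatter. Nothing at hand accounts for the step at the new position.

An ethoxy or an amine here could show whether the oxygen or the chain length tracks with the half-life. From the compounds shown here alone, whether the step carries over to the 1,3-benzothiazol-2-yl series of compound 2 remains open.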